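Ether Substituent Swap on a Shared Core

This account rests on a few compounds, and the source may have more. Where it says the series, first, only, none or still open, it means among the compounds named here.

Measured compounds:
compound 1 `Cc1nn(-c2ncnc3nc[nH]c23)c2c1C(OCC(=O)c1ccc(F)cc1)CC(=O)N2`: 3 nM
compound 2 `Cc1nn(-c2ncnc3nc[nH]c23)c2c1C(OC1CCCC1)CC(=O)N2`: 2 nM

In a functional assay on HEK293 cells for agonist activity at G-protein coupled receptor 39 (Homo sapiens), read by scintillation proximity assay and inositol phosphate accumulation, with a stated time of 75 min, in the presence of a further agent that is not named here (a higher number here means that more compound is needed for the effect, a lower number that less compound is needed), compound 2 gives the lowest of the two numbers, with compound 1 a near neighbour within the scatter. Compound 3 `Cc1nn(-c2ncnc3nc[nH]c23)c2c1C(OCCc1ccccc1)CC(=O)N2` differs from compound 2 by phenethyl in place of cyclopentyl on an oxygen on a saturated carbon. Within the data shown here, the one step that bears on this position, a 1.5-fold lower number from compound 1 to compound 2 (0.18 log units; within the scatter), changed the ether substituent without moving the number beyond the scatter. For compound 3 a step of a 1.5-fold higher number from compound 2 to compound 3 (0.18 log units; within the scatter) is therefore expected, that is no change beyond the scatter. Compound 3 is estimated at 3 nM, with a range from 1 nM to 10 nM.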

Compound 3, half-maximal effective concentration: 3 nM
Beside the measured number, compound 3's estimate shows no gap at the digits printed; low and high end bracket the measured number.
By their numbers in this assay, from the lowest: compounds 2, 1 and 3 (each within the scatter of the next).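

In this assay, phenethyl in place of cyclopentyl gives a 1.5-fold higher number from compound 2 to compound 3 (0.18 log units; within the scatter), so the oxygen on the saturated carbon carries an aromatic ring on a chain as well as a non-aromatic ring with no change beyond the scatter. Benzyl in place of (4-fluorophenyl)carbonyl gives no change at the digits printed from compound 1 to compound 3 (within the scatter), so this exchange on the chain also leaves the number within the scatter. Nothing at hand speaks to why these groups read alike. The compounds shown leave open whether an amine, a carboxylic acid or a longer chain at this oxygen would hold the number in the same way.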